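The compounds below may be only part of what the source reports. "The series", "measured", "known", "first", "only" and "open" are said of these compounds alone.

For the measured compounds named here, compound 3 `NC(=O)c1cc(NC(=O)c2cnc(Cl)nc2C(F)(F)F)cc(C(F)(F)F)c1` stands second highest of the three numbers so far in an assay on Jurkat cells for inhibition of cyclic AMP-dependent transcription factor ATF-1 (Homo sapiens) (on this read-out lower numbers stand for stronger inhibition and higher numbers for weaker inhibition), where compound 3 gives 3000 nM. Its nearest neighbour is compound 1 `Cc1cc(NC(=O)c2cnc(Cl)nc2C(F)(F)F)on1`, which in this assay gives 3800 nM, within the scatter of compound 3; furthest is compound 2 `O=C(Nc1cc(C(F)(F)F)cc(C(F)(F)F)c1)c1cnc(Cl)nc1C(F)(F)F`, which in this assay gives 50 nM. Compound 4 `CCOC(=O)c1cc(NC(=O)c2cnc(Cl)nc2C(F)(F)F)cc(C(F)(F)F)c1` differs from compound 3 by ethoxy in place of amino on a carbonyl carbon. Going by the values given here, the only measured step that bears on it is a 60-fold higher number from compound 2 to compound 3 (1.78 log units; beyond the scatter), which shows that the group on that aromatic carbon can move the number a long way. Compound 4 keeps a carbonyl there, so only a modest change is expected, estimated as a 2.0-fold lower number from compound 3 to compound 4 (0.30 log units; within the scatter). Compound 4 is therefore expected to give about 1500 nM in this assay, within 400 nM to 5000 nM.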

Compound 4, half-maximal inhibitory concentration: 150 nM
Compound 4: middle estimate off by 10-fold (1.00 log units), on the high side, outside the stated range (below it).
By their numbers in this assay, from the lowest: compound 2; then compound 4; then compounds 3 and 1 (each within the scatter of the next).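

In this assay, keeping the carbonyl on the aromatic carbon does not fix the number: ethoxy in place of amino on the carbonyl carbon gives a 20-fold lower number from compound 3 to compound 4 (1.30 log units; beyond the scatter), so the group on that carbon has a large bearing on it. Ethoxycarbonyl stays close to trifluoromethyl, with a 3.0-fold higher number from compound 2 to compound 4 (0.48 log units; beyond the scatter), though the gap is still beyond the scatter. Nothing given here explains the difference between amino and ethoxy. From the compounds shown here alone, what methoxy, a longer chain or a hydroxyl group, as in a carboxylic acid, would do on that carbonyl carbon remains open.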